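The source may report more compounds than this note shows. Statements on the series, on what has been measured and on what is new or still open speak of the compounds shown alone.

Measured so far in a functional assay on HepG2 cells (Homo sapiens) for cytotoxicity, read by MTT assay, with a stated time of 48 h; a lower number here means a stronger inhibitor, a higher number a weaker inhibitor:

- compound 1, `CNC(=O)CSc1nc2ccc(NC(=O)c3ccccc3OC)cc2s1`; in this assay compound 1 gives 18500 nM
- compound 2, `COc1ccc(CNC(=O)CSc2nc3ccc(NC(=O)c4ccc(Cl)cc4)cc3s2)cc1`; in this assay compound 2 gives 7400 nM

Compound 2 holds the lower of the two numbers shown; the only neighbour is compound 1, whose number is higher by a step that goes beyond the scatter. The two compounds differ at more than one place, so their values are only compared side by side, with nothing to say about the source of the gap.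

Compound 3, `O=C(CSc1nc2ccc(NC(=O)c3ccc(Cl)cc3)cc2s1)NCc1ccc(Cl)cc1`, has not yet been measured in this assay. It departs from compound 2 by a single change: chloro in place of methoxy on an aromatic carbon, that is, 4-methoxybenzyl becomes 4-chlorobenzyl on the amide side of the shared core. Within the data shown here, no step of this kind between two measured compounds exists, so there is no measured precedent for its size. The expectation is a step within the scatter, in either direction or none at all, with the chloro analogue landing close to compound 2.

On that basis compound 3 is expected to give about 6000 nM in this assay, with a range of 2500 nM to 15000 nM, which corresponds to an estimated step of a 1.2-fold lower number from compound 2 to compound 3 (0.09 log units; within the scatter).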

Compound 3, half-maximal inhibitory concentration: 17800 nM
Estimate against measurement, compound 3: 3.0-fold (0.47 log units) below; measured number outside the range, above it.
By their numbers in this assay, from the lowest: compound 2; then compounds 3 and 1 (each within the scatter of the next).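

In this assay, among these compounds, the group on the amide side of the shared core is not neutral to this exchange: chloro in place of methoxy, para to a large group on the six-membered aromatic ring, gives a 2.4-fold higher number from compound 2 to compound 3 (0.38 log units; beyond the scatter) as the first single-place step, modest in size but beyond the scatter. The earlier comparison of compound 1 and compound 2 could assign its gap to no one place, whereas this pair ties a change in the number to 4-methoxybenzyl becoming 4-chlorobenzyl, with compound 2 holding the lower number of the two. No accompanying measurement bears on the origin of this step, so the pair records its size and direction only.

Going by these compounds, with only methoxy and chloro compared at this place, it remains open whether the step reflects the departure of methoxy, the arrival of chloro, or both. A plain benzyl, a hydroxy group or an amine on the same aromatic carbon, or a longer chain linking the ring to the amide nitrogen, would help to separate these readings and show how far this single step extends across the series.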